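A few compounds are considered here, and "the series" means these few. Any claim that something is new, unique, unknown or untested is made for them only; others in the source may bear on it.

Compound 1 `COc1ccc2[nH]c(C(=O)N3CC(=O)N(Cc4ccccc4)[C@@H](COc4ccccc4)C3)cc2c1`: in an ADME assay on Vero cells (Chlorocebus sabaeus) for cytotoxicity, with a stated time of 7 days (a lower number here means that less compound is tolerated, a higher number that more compound is tolerated), compound 1 gives > 10000 nM, which is a limit of the assay rather than a number.
Compound 2 `COc1ccc2[nH]c(C(=O)N3CC(=O)N(Cc4ccccc4)[C@@H](COc4ccc(F)cc4)C3)cc2c1`: in this assay compound 2 gives 33200 nM.

Compound 2 thus holds the only number shown in this assay; the one other value is a limit (the limit of > 10000 nM in this assay, at which 1 of the 2 values shown sits). The step that the limit leaves unreadable from compound 1 to compound 2 cannot be read because of the limit of > 10000 nM in this assay, at which 1 of the 2 values shown sits. Compound 3 `COc1ccc2[nH]c(C(=O)N3CC(=O)N(Cc4ccccc4)[C@@H](CN4CCN(c5ccccn5)CC4)C3)cc2c1` differs from compound 2 by 4-(pyridin-2-yl)piperazin-1-yl in place of 4-fluorophenoxy on a saturated chain carbon bound to a saturated ring carbon. No readable measured step bears on this change, so no shift beyond the scatter is expected, and the step of a 1.1-fold lower number from compound 2 to compound 3 (0.04 log units; within the scatter) is expected to be small. Compound 3 is estimated at 30000 nM, with a range from 10000 nM to 100000 nM.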

Compound 3, half-maximal cytotoxic concentration: > 30000 nM
Compound 3 ended at the assay's limit; the forecaster's own chance of this, stated with the estimate: 30%; the middle value lies on the limit itself.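

Compound 3 ends at a limit of the assay rather than a number, so its steps from compound 1 and compound 2 cannot be read: the limit of > 30000 nM in this assay, at which 1 of the 3 values shown sits.

The compounds shown leave open how far 4-(pyridin-2-yl)piperazin-1-yl in place of 4-fluorophenoxy or phenoxy shifts the number in this assay.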